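Aryl amide swap in the shared-core series, compound 2 to 4

A few compounds are considered here, and "the series" means these few. Any claim that something is new, unique, unknown or untested is made for them only; others in the source may bear on it.

Compound 1 `COc1cccc(OC)c1C(=O)Nc1c[nH]nc1C(=O)NC1CC1`, compound 2 `CO[C@H]1CC[C@H](NC(=O)c2n[nH]cc2NC(=O)c2cc(Cl)cc(Cl)c2)CC1` and compound 3 `COc1cccc(OC)c1C(=O)Nc1c[nH]nc1C(=O)NC1CCN(C(=O)OC(C)(C)C)CC1` share one core and differ in the amide-bearing groups at either end. In an ADME assay on MRC5 cells (Homo sapiens) for inhibition, with a stated time of 72 h (a lower number here means that less compound is needed, a higher number that more compound is needed for the effect), compound 1 gives > 50000 nM, which is a limit of the assay and not a number. Compound 3 gives > 50000 nM in this assay, again a limit. Compound 2 gives 13000 nM in this assay and so stands as the only numerical result in the set, while the two other entries sit at the limit of > 50000 nM in this assay, at which 2 of the 3 values shown sit. Compound 4 `CO[C@H]1CC[C@H](NC(=O)c2n[nH]cc2NC(=O)c2cc3ccccc3o2)CC1` differs from compound 2 in a single place: 1-benzofuran-2-yl in place of 3,5-dichlorophenyl on a carbonyl carbon. Going by the values given here, no step between two measured compounds is available here, so the size of this change cannot be read from the data. The expected step of a 1.2-fold higher number from compound 2 to compound 4 (0.09 log units; within the scatter) is taken as lying within the usual scatter, with some chance of drifting towards the limit. For compound 4 the estimated value in this assay is 16000 nM, with a range from 5000 nM to 50000 nM.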

Compound 4, half-maximal effective concentration: 800 nM
For compound 4 the middle estimate is 20-fold (1.30 log units) above the measured one; the whole stated range lies above it.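

In this assay, going by these compounds alone, 1-benzofuran-2-yl in place of 3,5-dichlorophenyl on a carbonyl carbon gives a 16-fold lower number from compound 2 to compound 4 (1.21 log units; beyond the scatter) as the first step that can be read in this set. The position is therefore not neutral in this assay: with the rest of the structure unchanged, the swap of this one group moves the result well beyond the scatter. No measurement shown accounts for the size of this step.

The compounds shown leave open whether the lower number follows the five-membered aromatic ring, its oxygen or the loss of the two chlorine atoms. Also open, as far as these compounds go, are how an unsubstituted phenyl, a furan-2-yl or an aryl group carrying an amine would read at this position, and whether the same swap holds with other groups at the far amide end.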